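This account rests on a few compounds, and the source may have more. Where it says the series, first, only, none or still open, it means among the compounds named here.

Compound 1 `O=C(NCCCCc1ccccc1)c1cccc(C2SCC(=O)N2c2ccccn2)c1` gives 19.7 nM in a functional assay on HOS-TE85 cells (Homo sapiens) for inhibition, read by CCK-8 assay, with a stated time of 72 h; a lower number here means a stronger inhibitor, a higher number a weaker inhibitor. Compound 2 `COc1c(F)cccc1N1C(=O)CSC1c1cccc(C(=O)NCCCCc2ccccc2)c1` gives 26.2 nM in this assay. Compound 3 `O=C(NCCCCc1ccccc1)c1cccc(C2SCC(=O)N2c2ccccc2)c1` gives 15.9 nM in this assay.

Compound 3 holds the lowest of the three numbers, yet a 1.2-fold lower number from compound 1 to compound 3 (0.09 log units; within the scatter) and a 1.6-fold lower number from compound 2 to compound 3 (0.22 log units; within the scatter) both stay within the scatter, so the three compounds cannot be ordered. Compound 4 `O=C(NCCCCc1ccccc1)c1cccc(C2SCC(=O)N2c2ccc(C3CC3)cc2)c1` differs from compound 3 by cyclopropyl in place of hydrogen on an aromatic carbon. Among the compounds with values here, no measured step adds a group to the phenyl itself; the measured steps exchange the whole aromatic ring on the amide-type nitrogen, and each of them, a 1.3-fold higher number from compound 1 to compound 2 (0.12 log units; within the scatter) included, lies within the scatter. The account therefore expects a 1.1-fold higher number from compound 3 to compound 4 (0.03 log units; within the scatter), no step beyond the scatter in this assay. For compound 4 the estimate in this assay is 17 nM, expected between 8 nM and 36 nM.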

Compound 4, half-maximal inhibitory concentration: 217 nM
Estimate against measurement, compound 4: 13-fold (1.11 log units) below; measured number outside the range, above it.
By their numbers in this assay, from the lowest: compounds 3, 1 and 2 (each within the scatter of the next); then compound 4.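

Exchanging the whole aromatic ring on the amide-type nitrogen had stayed within the scatter, but in this assay adding cyclopropyl to the phenyl, para to a large group, does not (a 14-fold higher number from compound 3 to compound 4 (1.14 log units; beyond the scatter)). The other two ring exchanges also reach beyond the scatter once 4-cyclopropylphenyl enters (an 8.3-fold higher number from compound 2 to compound 4 (0.92 log units; beyond the scatter); an 11-fold higher number from compound 1 to compound 4 (1.04 log units; beyond the scatter)), so this ring does not accept every change. Nothing available gives a reason for this rise.

As far as these compounds go, whether methyl, a methoxy group or an amine at the same place would give a similar rise remains open. So does whether it follows from the cyclopropyl itself or from any group at this place.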